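The compounds below may be only part of what the source reports. "The series", "measured", "known", "first", "only" and "open" are said of these compounds alone.

Measured compounds:
Compound 1, `Cc1cc(=O)oc2cc(Oc3no[n+]([O-])c3S(=O)(=O)c3ccccc3)ccc12`: 2990 nM
Compound 2, `O=c1ccc2ccc(OCCOc3no[n+]([O-])c3S(=O)(=O)c3ccccc3)cc2o1`: 170 nM
Compound 3, `O=C(COc1ccc2ccc(=O)oc2c1)OCCOc1no[n+]([O-])c1S(=O)(=O)c1ccccc1`: > 20000 nM

All three share a coumarin-bearing core linked through an oxygen chain to a sulfonyl furoxan and were tested in a functional assay on A2780 cells (Homo sapiens) for antiproliferative activity, read by MTT assay, with a stated time of 48 h; on this read-out lower numbers stand for stronger inhibition and higher numbers for weaker inhibition. Compound 2 gives 170 nM, whereas compound 1 gives 2990 nM; the two differ in more than one place, so only their two values can be set side by side, without a counted step between them. Compound 3 is reported only as a limit, > 20000 nM, not as a number. Compound 3 therefore stands at the limit of > 20000 nM in this assay, at which 1 of the 3 values shown sits, the weak end of everything shown here.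

Compound 4, `Cc1cc(=O)oc2cc(OCC(=O)OCCOc3no[n+]([O-])c3S(=O)(=O)c3ccccc3)ccc12`, is the next compound to be measured. It differs from compound 3 by methyl in place of hydrogen on an aromatic carbon. Among the measured compounds shown here, no pair of measured compounds shows this single change on its own, so its effect has to be judged without a measured step. Because compound 3 sits at > 20000 nM, compound 4 is expected to stay close to that limit, with a step that the limit leaves unreadable from compound 3 to compound 4 expected to be no larger than the scatter. Compound 4 is thus estimated at 25000 nM, within a range of 8000 nM to 60000 nM.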

Compound 4, half-maximal inhibitory concentration: 3650 nM
Estimate against measurement, compound 4: 6.8-fold (0.84 log units) above, and the stated range ends above it.
By their numbers in this assay, from the lowest: compound 2; then compounds 1 and 4 (each within the scatter of the next). At a limit, above all of these: compound 3.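

In this assay, among the compounds shown here, methyl in place of hydrogen on an aromatic carbon, opposite the ring oxygen, is the first single change that can be read in this set, and it gives an at least 5.4-fold lower number from compound 3 to compound 4 (0.73 log units; beyond the scatter). For the compounds shown here, this shows that the position is not silent: with the rest of the structure unchanged, one added carbon is enough to bring compound 4 to a measured number, where the earlier compounds offered no step at all and so said nothing about this place. The true size of the step remains unknown, and the printed figure is only a lower bound, because compound 3 is held at a limit and not at a number: the limit of > 20000 nM in this assay, at which 1 of the 4 values shown sits.

The compounds shown leave open whether this position accepts only methyl or also other groups, such as ethyl, a chlorine atom or a methoxy group, and how these would stand against the hydrogen of compound 3 and the methyl of compound 4. They also leave open whether the same methyl would produce a comparable step on the shorter chain of compound 2, which carries no ester.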